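The source may hold more compounds than are shown below. What is called first, only, known or untested is meant among the compounds shown, and "the series" means these compounds.

Measured so far in an ADME assay on HepG2 cells (Homo sapiens) for cytotoxicity, read by luminescence, CellTiter-Glo and ATP content, with a stated time of 72 h; on this read-out lower numbers stand for an effect already at smaller amounts and higher numbers for an effect only at larger amounts of compound:
compound 1 `c1ccc(Oc2ccc3c(NCCCNCc4ccco4)ccnc3c2)cc1`, 15200 nM
compound 2 `CC(C)(C)c1ccc(Oc2ccc3c(NCCCNCc4ccco4)ccnc3c2)cc1`, 3100 nM
compound 3 `CC(C)(C)c1ccc(-c2ccc3c(NCCCNCc4ccco4)ccnc3c2)cc1`, 3150 nM

Compound 3 stands second highest of the three numbers; its step to compound 2 lies within the scatter, and compound 1 sits a good way higher.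

Compound 4 `Clc1ccc(Oc2ccc3c(NCCCNCc4ccco4)ccnc3c2)cc1` differs from compound 3 in one place: 4-chlorophenoxy in place of 4-(tert-butyl)phenyl on an aromatic carbon. Going by the values given here, two measured steps bear on this. The step of a 4.8-fold lower number from compound 1 to compound 3 (0.68 log units; beyond the scatter) shows what the 4-(tert-butyl)phenyl group that now leaves was worth against plain phenoxy. The step of a 4.9-fold lower number from compound 1 to compound 2 (0.69 log units; beyond the scatter) shows a similar gain from tert-butyl on the same aromatic carbon. Among the compounds with values here, the entering 4-chlorophenoxy has no direct precedent here; it lies between compound 1 and the substituted analogues. A modest upward step in this assay, a 2.4-fold higher number from compound 3 to compound 4 (0.38 log units; beyond the scatter), is therefore expected, and compound 4 is estimated at 7500 nM, within 3000 nM to 18000 nM.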

Compound 4, half-maximal effective concentration: 7800 nM
The estimate for compound 4 lay 1.0-fold (0.02 log units) below the measured number; measured number inside the range.
By their numbers in this assay, from the lowest: compounds 2 and 3 (each within the scatter of the next); then compounds 4 and 1 (each within the scatter of the next).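

In this assay the change of tert-butyl to chloro gives a 2.5-fold higher number from compound 2 to compound 4 (0.40 log units; beyond the scatter) and so is not neutral at this place. Chloro in place of hydrogen gives a 1.9-fold lower number from compound 1 to compound 4 (0.29 log units; within the scatter) and cannot be told apart from plain phenoxy, unlike tert-butyl. 4-chlorophenoxy in place of 4-(tert-butyl)phenyl gives a 2.5-fold higher number from compound 3 to compound 4 (0.39 log units; beyond the scatter) as well, so among these four compounds the lower numbers belong to the two carrying tert-butyl, with or without the phenoxy oxygen.

Nothing shown explains these steps. Open, on these data alone, is where a methoxy, a trifluoromethyl or an amine on that aromatic carbon would fall relative to chloro and tert-butyl.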